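The compounds below may be only part of what the source reports. "The series", "measured", "known", "first", "only" and "open" are said of these compounds alone.

Working notes on the series. In a functional assay on RAW264.7 cells (Mus musculus) for inhibition, read by Griess assay, with stated times of 1 h and 24 h (on this read-out higher numbers stand for weaker inhibition and lower numbers for stronger inhibition), compound 1 (`O=C1OC(Cc2nc(-c3ccc(-c4ccccc4)cc3)no2)c2ccccc21`) gives > 10000 nM, and this is a limit of the assay, not a number. Within the data shown here, compound 2 (`CCCCOc1ccc(C(O)C2OC(=O)c3c(OC)cc(OC)cc32)cc1`) gives 1800 nM, the only actual number so far, so it is the sole numerical reference point for this series. Among the measured compounds shown here, the two measured compounds differ in more than one place, so no measured step is available to calibrate the next change.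

Compound 3 (`C=CCCOc1ccc(C(O)C2OC(=O)c3c(OC)cc(OC)cc32)cc1`) keeps everything in compound 2 except the end of the butoxy chain, which becomes (but-3-en-1-yl)oxy: vinyl in place of ethyl on a saturated chain carbon, two bonds along the chain from an oxygen on an aromatic ring. In words, vinyl takes the place of ethyl on a saturated chain carbon, two bonds along the chain from an oxygen on an aromatic ring.

For the measured compounds named here, with no comparable step to draw on, the expectation in this assay starts from compound 2 at 1800 nM, and no shift beyond the scatter is expected in either direction. The expected step of no change at the digits printed from compound 2 to compound 3 (within the scatter) is therefore small. The estimated value for compound 3 is 1800 nM, with an expected range of 800 nM to 4000 nM.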

Compound 3, half-maximal inhibitory concentration: 1330 nM
Compound 3: middle estimate off by 1.4-fold (0.13 log units), on the high side; measured number inside the range.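

In this assay, among these compounds, the change of vinyl in place of ethyl on a saturated chain carbon, two bonds along the chain from an oxygen on an aromatic ring, gives the first readable step: a 1.4-fold lower number from compound 2 to compound 3 (0.13 log units; within the scatter). This position therefore accepts a double bond outside aromatic rings, with the heavy-atom count of the group unchanged, without a shift beyond the scatter, and the pair gives a measured reference for later changes at this place. Among the compounds shown here, nothing available gives a cause for this step, and the single step does not show how the read-out responds to a larger change here.

The compounds shown leave open whether a longer chain such as hexyloxy, or a chain ending in an amine or a carboxylic acid, in place of butoxy would move the number beyond the scatter. They also leave open whether a much shorter group such as methoxy at this oxygen would keep the read-out, and so how much of the butoxy chain is needed at all.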